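A few compounds are considered here, and "the series" means these few. Any claim that something is new, unique, unknown or untested is made for them only; others in the source may bear on it.

Compound 1 `Cn1cc(C2CC(c3ccc(F)cc3)=NN2C(=O)c2cccnc2)c2cc(Br)ccc21` gives 1380 nM
Compound 2 `Cn1cc(C2CC(c3ccc(Cl)cc3)=NN2C(=O)c2cccnc2)c2cc(Br)ccc21` gives 7650 nM

In a functional assay on A549 cells (Homo sapiens) for inhibition, read by MTT assay, with a stated time of 48 h (on this read-out higher numbers stand for weaker inhibition of growth and lower numbers for stronger inhibition of growth), compound 2, at 7650 nM, has the higher of the two numbers. Compound 3 `Cn1cc(C2CC(c3ccc(Br)cc3)=NN2C(=O)c2cccnc2)c2cc(Br)ccc21` differs from compound 2 as follows: bromo in place of chloro on an aromatic carbon. Going by the values given here, one measured step bears on this, the change of chloro in place of fluoro on an aromatic carbon: a 5.5-fold higher number from compound 1 to compound 2 (0.74 log units; beyond the scatter). A single step sets no trend, so no step beyond the scatter is expected in this assay, and no direction is favoured. The expected change is a 1.2-fold lower number from compound 2 to compound 3 (0.07 log units; within the scatter). For compound 3 the estimate is 6500 nM, within an expected range from 2200 nM to 20000 nM.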

Compound 3, concentration for 50% growth inhibition: > 10000 nM
Compound 3 ended at the assay's limit; the forecaster's own chance of this, stated with the estimate: 5%; middle value at least 1.5-fold (0.18 log units) from the limit.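

In this assay, the result for compound 3 is a limit of the assay, not a number: the limit of > 10000 nM in this assay, at which 1 of the 3 values shown sits. Bromo in place of fluoro gives an at least 7.2-fold higher number from compound 1 to compound 3 (0.86 log units; beyond the scatter), so at this place on the ring compound 1, with fluoro, now stands apart from both the chloro and the bromo compound. Bromo in place of chloro gives an at least 1.3-fold higher number from compound 2 to compound 3 (0.11 log units; that floor lies within the scatter), so these two halogens cannot be put in order. Still open, as far as these compounds go, is how far compound 3 lies past its limit. Also open, from the compounds shown here alone, is whether another group here, such as an amine or a carboxylic acid, would give a lower number than compound 1.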